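The compounds below may be only part of what the source reports. "The series", "measured", "known", "first", "only" and "open" are said of these compounds alone.

Measured so far:
Compound 1 `Nc1ccccc1NC(=O)c1ccc(Cn2cnc3c(Nc4ccccc4)nc(Cl)nc32)cc1`: 5740 nM
Compound 2 `Nc1ccccc1NC(=O)c1ccc(CNc2nc(Cl)nc3c2ncn3C2CCCC2)cc1`: 5780 nM

For the measured compounds named here, in a functional assay on NCI-H460 cells (Homo sapiens) for antiproliferative activity, read by CCK-8 assay, with a stated time of 72 h (on this read-out lower numbers stand for stronger inhibition and higher numbers for weaker inhibition), compound 1 gives 5740 nM, which lies within the scatter of the only other measured value, so neither compound stands apart. Compound 2 differs from compound 1 in more than one place, yet compound 2 gives 5780 nM, and the two values show no separation.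

Compound 3 `CN1CCN(c2nc(Cl)nc3c2ncn3Cc2ccc(C(=O)Nc3ccccc3N)cc2)CC1` is the next case, with 4-methylpiperazin-1-yl in place of anilino on an aromatic carbon of the core: 4-methylpiperazin-1-yl in place of anilino on an aromatic carbon. Going by the values given here, no measured pair isolates this change, so the data give no firm direction. A step no larger than the scatter is expected, with a slightly lower number as a weak guess. The expected change is a 1.3-fold lower number from compound 1 to compound 3 (0.11 log units; within the scatter). For compound 3 the estimate is 4500 nM, with an expected range of 1500 nM to 14000 nM.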

Compound 3, half-maximal inhibitory concentration: 6160 nM
The estimate for compound 3 lay 1.4-fold (0.14 log units) below the measured number; measured number inside the range.
By their numbers in this assay, from the lowest: compounds 1, 2 and 3 (each within the scatter of the next).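

In this assay, the aromatic carbon next to the ring nitrogen now has its first comparison that differs in one place only, with 4-methylpiperazin-1-yl in place of anilino: a 1.1-fold higher number from compound 1 to compound 3 (0.03 log units; within the scatter). At this position, for this pair, exchanging one six-membered aromatic ring of carbon only for one six-membered non-aromatic ring with 2 hetero atoms, and 1 hydrogen-bond donor for 0 hydrogen-bond donors, leaves the two values unseparated. Nothing at hand explains this lack of separation.

Still open, as far as these compounds go, is whether this tolerance extends to a carboxylic acid or a morpholin-4-yl group on the same carbon, or to a longer chain in place of the methyl of 4-methylpiperazin-1-yl. Also open, from the compounds shown here alone, is whether an amine in place of the chloro group would separate the values.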